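The source may report more compounds than this note shows. Statements on the series, on what has been measured and on what is new or still open speak of the compounds shown alone.

Three measured compounds share one core and differ only in the aryl group on the carbonyl carbon. Compound 1 `Cn1cnc(S(=O)(=O)N2C[C@@H]3[C@H](C2)[C@@]3(CNC(=O)c2cc(Cl)cc(Cl)c2)CC2CC2)c1` carries 3,5-dichlorophenyl there and gives 100 nM in an assay on isolated protein for inhibition of sodium- and chloride-dependent glycine transporter 1 (Homo sapiens); on this read-out higher numbers stand for weaker inhibition and lower numbers for stronger inhibition. Compound 2 `Cn1cnc(S(=O)(=O)N2C[C@@H]3[C@H](C2)[C@@]3(CNC(=O)c2ccccc2Cl)CC2CC2)c1`, with 2-chlorophenyl, gives 19 nM in this assay, and compound 3 `Cn1cnc(S(=O)(=O)N2C[C@@H]3[C@H](C2)[C@@]3(CNC(=O)c2ccccc2C(F)(F)F)CC2CC2)c1`, with 2-(trifluoromethyl)phenyl, gives 5 nM in this assay. Compound 3 holds the lowest number of the three: the steps of a 20-fold lower number from compound 1 to compound 3 (1.30 log units; beyond the scatter) and a 3.8-fold lower number from compound 2 to compound 3 (0.58 log units; beyond the scatter) both lie beyond the scatter, as does a 5.3-fold lower number from compound 1 to compound 2 (0.72 log units; beyond the scatter).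

Compound 4 `Cn1cnc(S(=O)(=O)N2C[C@@H]3[C@H](C2)[C@@]3(CNC(=O)c2c(Cl)cccc2Cl)CC2CC2)c1` has not yet been measured. It differs from compound 3 in one place: 2,6-dichlorophenyl in place of 2-(trifluoromethyl)phenyl on a carbonyl carbon. The step that bears most directly on this change is a 3.8-fold lower number from compound 2 to compound 3 (0.58 log units; beyond the scatter), which shows that trifluoromethyl on that ring gave a lower number than chloro; undoing that exchange would be expected to cost a modest amount. Among the compounds with values here, no measured compound carries 2,6-dichlorophenyl, so the second chloro that enters has no direct counterpart, yet both singly substituted rings, in compound 2 and compound 3, sit far below compound 1. The step expected in this assay is therefore a 2.4-fold higher number from compound 3 to compound 4 (0.38 log units; beyond the scatter), a modest rise. Compound 4 is estimated at 12 nM in this assay, with a range from 4 nM to 40 nM.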

Compound 4, half-maximal inhibitory concentration: 28 nM
The estimate for compound 4 lay 2.3-fold (0.37 log units) below the measured number, within the range that was stated.
By their numbers in this assay, from the lowest: compound 3; then compounds 2 and 4 (each within the scatter of the next); then compound 1.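

Adding chloro to the 2-chlorophenyl ring gives a 1.5-fold higher number from compound 2 to compound 4 (0.17 log units; within the scatter) in this assay and so has no readable effect at this position, a result the singly substituted rings could not show. Replacing 2-(trifluoromethyl)phenyl with 2,6-dichlorophenyl gives a 5.6-fold higher number from compound 3 to compound 4 (0.75 log units; beyond the scatter) and leaves compound 3 with the lowest number of the four, so neither of the two chloro-bearing rings tested against it here matches the trifluoromethyl-bearing ring. The two dichlorophenyl rings carry the same atoms in different places, and the step from 3,5-dichlorophenyl to 2,6-dichlorophenyl gives a 3.6-fold lower number from compound 1 to compound 4 (0.55 log units; beyond the scatter) and thus shows that the arrangement of the two chloro groups on this ring matters, not merely their presence.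

The compounds shown leave open whether a 2-methoxyphenyl, a 2-cyanophenyl or a 2,6-bis(trifluoromethyl)phenyl group on the carbonyl carbon would match or pass the number of compound 3, and whether the order of these aryl groups would hold on a core with another group in place of the cyclopropylmethyl chain. Nothing presented here accounts for why these rings differ in this way.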